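The compounds below may be only part of what the source reports. "The series", "measured", "known", "first", "only" and "open" are said of these compounds alone.

The measured compounds:
- compound 1 `COc1cc(C)cc(-c2c(-c3ccnc(-c4ccc(C(C)=O)cc4)c3)cnn2CC#N)c1`: 95%
- compound 2 `Cc1cc(O)cc(-c2nn(CC#N)cc2-c2ccnc(-c3ccc(Oc4ccccc4)cc3)c2)c1`: 96%
- compound 3 `Cc1cc(O)cc(-c2nn(CC#N)cc2-c2ccnc(-c3ccc(N(C)C)cc3)c2)c1`: 98%

In a functional assay on NCI-H23 cells (Homo sapiens) for cytotoxicity, read by sulforhodamine B assay, with a stated time of 48 h, tested at 100 nM (a lower number here means a stronger effect, a higher number a weaker effect of the compound at the concentration tested), compound 1 shows the lowest of the three numbers, yet compound 2 and compound 3 lie within the usual scatter of it, so no real separation is seen among them. Compound 4 `COc1cc(C)cc(-c2c(-c3ccnc(-c4ccc(N(C)C)cc4)c3)cnn2CC#N)c1` differs from compound 1 by dimethylamino in place of acetyl on an aromatic carbon, at an aromatic carbon of a six-membered aromatic ring of carbon only. Among the measured compounds shown here, the only comparable step, dimethylamino in place of phenoxy on an aromatic carbon, gave a number 2 percentage points higher from compound 2 to compound 3 (within the scatter). For the measured compounds named here, no step from acetyl to dimethylamino has been measured. The expectation for compound 4 is therefore a move of a number 1 percentage points higher from compound 1 to compound 4 (within the scatter), nothing beyond the scatter. Compound 4 is estimated at 96%, between 88% and 104%.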

Compound 4, a percentage reported as activity, at one concentration (the size of the read-out at that concentration, not a potency): 28%
The estimate for compound 4 lay 68 percentage points above the measured number, outside the stated range (below it).
By their numbers in this assay, from the lowest: compound 4; then compounds 1, 2 and 3 (each within the scatter of the next).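

In this assay, the 4-acetylphenyl to 4-(dimethylamino)phenyl change gives a number 67 percentage points lower from compound 1 to compound 4 (beyond the scatter), so this aromatic carbon, para to a large group, can strongly affect the read-out even though both groups have the same count of heavy atoms. Dimethylamino does not bring such a shift in every comparison: a number 2 percentage points higher from compound 2 to compound 3 (within the scatter). Nothing measured here explains the large step.

As far as these compounds go, it remains open how far the effect depends on dimethylamino itself. A primary amine, a morpholine or a carboxylic acid at this carbon could help to show this.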